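Methoxy analog of compound 1 in the cytotoxicity series

The compounds below may be only part of what the source reports. "The series", "measured", "known", "first", "only" and "open" are said of these compounds alone.

Measured so far:
compound 1 `OCc1cn(Cc2ccccc2)c2ccccc12` — 112 nM
compound 2 `Cc1cccc(Cn2cc(CO)c3ccccc32)c1` — 31 nM
compound 3 `O=[N+]([O-])c1cccc(Cn2cc(CO)c3ccccc32)c1` — 39 nM

In a functional assay on NCI-H460 cells (Homo sapiens) for cytotoxicity, read by sulforhodamine B assay, with a stated time of 3 days (on this read-out higher numbers stand for weaker inhibition and lower numbers for stronger inhibition), compound 1 gives the highest of the three numbers. Adding a group to the benzyl ring lowered the number in both measured cases: a 3.6-fold lower number from compound 1 to compound 2 (0.56 log units; beyond the scatter) and a 2.9-fold lower number from compound 1 to compound 3 (0.46 log units; beyond the scatter). Compound 2 and compound 3 are not separated from each other, since a 1.3-fold higher number from compound 2 to compound 3 (0.10 log units; within the scatter). So far a methyl and a nitro, two groups that differ strongly in kind, gave the same modest gain over the unsubstituted compound 1.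

Compound 4 `COc1ccc(Cn2cc(CO)c3ccccc32)cc1` is the next analog in this line. Relative to compound 1 the change is methoxy in place of hydrogen on an aromatic carbon. Among the compounds with values here, no measured step covers methoxy on this ring, so the expectation rests on the two substitutions already seen, both of which moved the number lower by a modest, similar amount. Within the data shown here, a comparable step is therefore expected for compound 4, lower in this assay, with the caveat that the one substituted pair measured so far shows no dependence on the nature of the group and nothing speaks to a different place on the ring.

For compound 4 the estimated step from compound 1 is a 2.5-fold lower number from compound 1 to compound 4 (0.40 log units; beyond the scatter). Compound 4 is expected to give about 45 nM in this assay, with a likely range from 18 nM to 110 nM.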

Compound 4, half-maximal inhibitory concentration: 79 nM
The estimate for compound 4 lay 1.8-fold (0.24 log units) below the measured number; the range from low to high includes it.
By their numbers in this assay, from the lowest: compounds 2 and 3 (each within the scatter of the next); then compounds 4 and 1 (each within the scatter of the next).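

In this assay, methoxy in place of hydrogen, para to a large group, gives a 1.4-fold lower number from compound 1 to compound 4 (0.15 log units; within the scatter) and so does not separate compound 4 from compound 1. Within the data shown here, this is the first substitution on this ring whose step stays within the scatter, whereas methyl gives a 3.6-fold lower number from compound 1 to compound 2 (0.56 log units; beyond the scatter) and nitro gives a 2.9-fold lower number from compound 1 to compound 3 (0.46 log units; beyond the scatter), so a lower number on substitution does not hold across the ring, and compound 4 is the exception to that pattern. Nothing on hand accounts for the methoxy step standing apart from the methyl and nitro steps.

Methoxy is seen only para to a large group, and the compounds shown cannot separate the effect of the group from that of its place on the ring, since no single group appears at more than one place. An amine, a carboxylic acid or a chlorine at this same place would show whether any group there gives a step beyond the scatter, and methoxy at another place on the ring would show whether the small step follows the group.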